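The source may hold more compounds than are shown below. What is called first, only, known or untested is meant among the compounds shown, and "the series" means these compounds.

Compound 1 `O=C(NCc1ccc(F)cc1)c1nc(Br)c2cccnc2c1NCCO` is a weak inhibitor in a functional assay on MDA-MB-435 cells (Homo sapiens) for cytotoxicity, read by MTT assay, with a stated time of 72 h; a higher number here means a weaker inhibitor, a lower number a stronger inhibitor. For compound 1 the assay reports only a limit, > 20000 nM. Compound 2 `C[C@@H](CO)Nc1nc(C(=O)NCc2ccc(F)cc2)c(O)c2ncccc12` likewise stops at a limit in this assay, > 20000 nM. Compound 3 `N[C@H]1CC[C@H](Nc2c(C(=O)NCc3cccs3)nc(Br)c3cccnc23)CC1` gives a number in this assay, 4100 nM. The values of compound 1 and compound 2 both stand at the limit of > 20000 nM in this assay, at which 2 of the 3 values shown sit. Compound 4 `COC(=O)CNc1c(C(=O)NCc2ccc(F)cc2)nc(Br)c2cccnc12` differs from compound 1 in one place: methoxycarbonyl in place of hydroxymethyl on a saturated chain carbon bound to a nitrogen on an aromatic ring. Within the data shown here, no pair of measured compounds shows what such a change does, so the expected step is small, in either direction, or none beyond the scatter. Compound 4 is estimated at 25000 nM in this assay, within a range from 8000 nM to 60000 nM. That estimate means an expected step that the limit leaves unreadable from compound 1 to compound 4.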

Compound 4, half-maximal inhibitory concentration: 10000 nM
Beside the measured number, compound 4's estimate is 2.5-fold (0.40 log units) above it; low and high end bracket the measured number.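

With methoxycarbonyl in place of hydroxymethyl on a saturated chain carbon bound to a nitrogen on an aromatic ring, this position gives a readable number in this assay. Compound 1 remains a limit, > 20000 nM. From the compounds shown here alone, the change gives an at least 2.0-fold lower number from compound 1 to compound 4 (0.30 log units; that floor lies within the scatter), so the true size of the step stays unknown, and the floor alone does not show a real gain.

Going by these compounds, whether a carboxylic acid at this place would lower the number further remains open. So does what a longer chain carrying the methoxycarbonyl would do.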